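Removing One Aromatic Fluoro from a Difluoro Alkyne Compound

A few compounds are considered here, and "the series" means these few. Any claim that something is new, unique, unknown or untested is made for them only; others in the source may bear on it.

Measured so far:
- compound 1, `CC(C)(F)[C@@H]1COc2ccc(F)cc2[C@@H]1C#Cc1ccccc1`: 36%
- compound 2, `CC(C)(F)[C@@H]1COc2c(F)cc(F)cc2[C@@H]1C#Cc1ccccc1`: 20%

In a functional assay on Thorax with Thoracic (Rattus norvegicus) as the target, tested at 10 uM (a lower number here means a weaker effect, a higher number a stronger effect of the compound at the concentration tested), compound 2 gives the lower of the two numbers; its nearest neighbour is compound 1, and the step of a number 16 percentage points lower from compound 1 to compound 2 (beyond the scatter) lies beyond the scatter. Compound 3, `CC(C)(F)[C@@H]1COc2c(F)cccc2[C@@H]1C#Cc1ccccc1`, is not yet measured. It differs from compound 2 by hydrogen in place of fluoro on an aromatic carbon. Going by the values given here, the only step seen so far, a number 16 percentage points lower from compound 1 to compound 2 (beyond the scatter), concerns a fluoro entering at a different aromatic carbon, so it bears on this change only loosely: it suggests that the count of fluoro groups on this ring matters, and that going back to a single fluoro may recover part of the lost activity. Compound 3 is therefore expected to show a rise of a number 10 percentage points higher from compound 2 to compound 3 (within the scatter) in this assay, with wide uncertainty. The estimate for compound 3 is 30%, ranging from 12% to 48%.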

Compound 3, a percentage reported as activity, at one concentration (the size of the read-out at that concentration, not a potency): 28%
Beside the measured number, compound 3's estimate is 2 percentage points above it, and the stated range covers the measured number.
By their numbers in this assay, from the lowest: compounds 2, 3 and 1 (each within the scatter of the next, the first and the last beyond it).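

In this assay, putting hydrogen in place of the fluoro on this aromatic carbon, meta to a fluoro group and para to a fused ring, gives a number 8 percentage points higher from compound 2 to compound 3 (within the scatter), so at this position, losing the fluoro produces no change that can be told apart from ordinary scatter. Going by these compounds alone, the earlier step, a number 16 percentage points lower from compound 1 to compound 2 (beyond the scatter), involved a fluoro entering at a different aromatic carbon, and only that step lies beyond the scatter, so the two positions need not respond alike. No measurement here offers an explanation for the size of either step.

On these data alone, whether a larger replacement at this carbon, such as a chlorine atom, a methoxy group or an amine, would shift the read-out remains open. Also open, as far as these compounds go, is how a compound with hydrogen at both of these aromatic carbons would compare with compound 3.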